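Swapping chloro for methoxy in a pair of sulfone compounds

This account rests on a few compounds, and the source may have more. Where it says the series, first, only, none or still open, it means among the compounds named here.

Compound 1 and compound 2 have so far been run in an ADME assay on microsomes from liver (Homo sapiens) for metabolic stability, tested at 2.5 uM; on this read-out higher numbers stand for fast clearance and lower numbers for slow clearance. Compound 1, `COc1cccc(-c2c(S(=O)(=O)c3ccc(C)c(F)c3)cnc3c(F)cccc23)c1`, gives 4.02 mL/min. Compound 2, `O=S(=O)(c1cc(F)cc(F)c1)c1cnc2c(F)cccc2c1-c1cccc(Cl)c1`, gives 0.64 mL/min, the lowest of the two numbers, with the gap to compound 1 lying beyond the usual scatter. Compound 3, `COc1cccc(-c2c(S(=O)(=O)c3cc(F)cc(F)c3)cnc3c(F)cccc23)c1`, has not yet been measured in this assay; its difference from compound 2 is methoxy in place of chloro on an aromatic carbon. Within the data shown here, no pair of measured compounds differs in only one place, so the size of this step must be judged from the two numbers alone. Among the measured compounds shown here, the only measured compound carrying methoxy is compound 1, whose number is 4.02 mL/min, so an upward step beyond the scatter is expected. The step from compound 2 to compound 3 is estimated as a 2.8-fold higher number from compound 2 to compound 3 (0.45 log units; beyond the scatter). For compound 3 the expected result is 1.8 mL/min, within a range of 0.7 mL/min to 4.5 mL/min.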

Compound 3, intrinsic clearance in a liver preparation (reported as CLH), per the amount of preparation that the assay uses: 2.76 mL/min
Compound 3: middle estimate off by 1.5-fold (0.19 log units), on the low side; the measured number falls inside the stated range.
By their numbers in this assay, from the lowest: compound 2; then compounds 3 and 1 (each within the scatter of the next).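

In this assay, among these compounds, the first single-place comparison at this position, 3-methoxyphenyl in place of 3-chlorophenyl, gives a 4.3-fold higher number from compound 2 to compound 3 (0.63 log units; beyond the scatter), so this one swap on the aromatic carbon is enough to move the number clearly. The other single-place comparison, 3,5-difluorophenyl in place of 3-fluoro-4-methylphenyl on the sulfonyl sulfur, gives a 1.5-fold lower number from compound 1 to compound 3 (0.16 log units; within the scatter), which leaves compounds 1 and 3 indistinguishable in this read-out. Nothing measured here explains why the methoxy and chloro compounds differ.

Only chloro and methoxy appear at this position among the compounds shown, so how a nitrile, a hydroxyl or an amine there would read remains open. Also open, as far as these compounds go, is whether the step from chloro to methoxy keeps its size with 3-fluoro-4-methylphenyl on the sulfonyl sulfur.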